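The source may hold more compounds than are shown below. What is called first, only, known or untested is meant among the compounds shown, and "the series" means these compounds.

Measured compounds and their values:

Compound 1, with the structure `Cc1ccc(C(=O)Nc2sc3c(c2C(N)=O)CCN(Cc2ccc(Cl)cc2Cl)C3)cc1`, gives 19900 nM in a functional assay on HL-60 cells (Homo sapiens) for antiproliferative activity, with a stated time of 24 h; on this read-out lower numbers stand for stronger inhibition and higher numbers for weaker inhibition.
Compound 2, with the structure `NC(=O)c1c(NC(=O)c2cccc([N+](=O)[O-])c2)sc2c1CCN(Cc1ccc(Cl)cc1Cl)C2`, gives 19800 nM in this assay.
Compound 3, with the structure `Cc1ccc(C(=O)Nc2sc3c(c2C(N)=O)CCN(C(=S)Nc2cc(C(F)(F)F)cc(C(F)(F)F)c2)C3)cc1`, gives 11800 nM in this assay.

Compounds 1 and 2 share one core and differ in a single place: 3-nitrophenyl in place of 4-methylphenyl on a carbonyl carbon. That change brought a 1.0-fold lower number from compound 1 to compound 2 (0.00 log units; within the scatter), so the two values cannot be told apart. Compound 3 carries a different core; the difference between the two cores is not broken down here. Its value and the values of compound 1 and compound 2 all lie within the usual scatter of one another, so no order among the three can be claimed.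

Compound 4, with the structure `NC(=O)c1c(NC(=O)c2cccc([N+](=O)[O-])c2)sc2c1CCN(C(=S)Nc1cc(C(F)(F)F)cc(C(F)(F)F)c1)C2`, has not yet been measured in this assay. It arises from compound 3 by the same change that turns compound 1 into compound 2: 3-nitrophenyl in place of 4-methylphenyl on a carbonyl carbon. The surroundings of the change are described in the same words for both pairs, so this is the same change on a different core.

Among the compounds with values here, only one earlier example of this change exists, and it left the number essentially where it was. On that basis alone, from compound 3 the expected step is a 1.0-fold higher number from compound 3 to compound 4 (0.01 log units; within the scatter). Compound 4 is therefore estimated to give 12000 nM in this assay. For compound 4 the estimate is expected to lie between 5000 nM and 30000 nM, the width reflecting that a single prior step on another core is thin evidence.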

Compound 4, half-maximal inhibitory concentration: 16400 nM
The estimate for compound 4 lay 1.4-fold (0.14 log units) below the measured number; the measured number falls inside the stated range.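

On the second core, putting 3-nitrophenyl in place of 4-methylphenyl on the carbonyl carbon gave a 1.4-fold higher number from compound 3 to compound 4 (0.14 log units; within the scatter), so in this assay these two values cannot be told apart. The same holds on the first core, and the two steps agree with each other: the same change on two cores in this assay, a 1.0-fold lower number (0.00 log units; within the scatter) from compound 1 to compound 2 and a 1.4-fold higher number (0.14 log units; within the scatter) from compound 3 to compound 4, 1.4-fold (0.15 log units) apart, within the scatter of two such steps This shows only that, on these two cores, the change moves the number by no more than repeated measurements would, so the agreement is between two steps that are each too small to read; it does not show that a change with a clear effect on one core would keep that effect on the other, and two pairs cannot speak for the whole series.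

Within the data shown here, only two aryl groups appear on this carbonyl carbon, so it remains open how the number would respond if either were replaced by a group of another kind, such as a phenyl ring bearing an amine or a carboxylic acid, or a longer alkyl chain. As far as these compounds go, all four compounds also keep the same carboxamide on the shared part of the structure, so what a nitrile in its place would do is equally open.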